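The source may hold more compounds than are shown below. What is called first, only, known or untested is meant among the compounds shown, and "the series" means these compounds.

Working notes on the series. Two members of this set have numbers in a functional assay on HCT-116 cells (Homo sapiens) for cytotoxicity, read by MTT assay, with a stated time of 72 h; a lower number here means a stronger inhibitor, a higher number a weaker inhibitor. Compound 1 `Cc1ccc(C)c(N2CCN(Cc3nnc(-c4cc(S(N)(=O)=O)c(SCc5ccccc5)cc4Cl)o3)CC2)c1` carries a piperazinylmethyl arm bearing a dimethylphenyl group on the shared core; in this assay compound 1 gives 17000 nM. Compound 2 `[N-]=[N+]=NCc1nnc(-c2cc(S(N)(=O)=O)c(SCc3ccccc3)cc2Cl)o1` carries an azidomethyl at the same place on the core; in this assay compound 2 gives 100000 nM. Of the two numbers, compound 2 holds the higher one, and its gap to compound 1 lies beyond the usual scatter.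

Compound 3 `NS(=O)(=O)c1cc(-c2nnc(/C=C/c3ccc(Br)cc3)o2)c(Cl)cc1SCc1ccccc1` is next for measurement. It differs from compound 2 as follows: 2-(4-bromophenyl)ethenyl in place of azidomethyl on an aromatic carbon. The change brings in a six-membered aromatic ring where compound 2 has none, as compound 1 also does. Going by compound 1 at 17000 nM against compound 2 at 100000 nM, a step toward a lower number is expected, and the step from compound 2 to compound 3 is estimated at a 5.0-fold lower number from compound 2 to compound 3 (0.70 log units; beyond the scatter). For compound 3 the expected value in this assay is 20000 nM, within a range of 5000 nM to 80000 nM.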

Compound 3, half-maximal inhibitory concentration: 15000 nM
The estimate for compound 3 lay 1.3-fold (0.12 log units) above the measured number; low and high end bracket the measured number.
By their numbers in this assay, from the lowest: compounds 3 and 1 (each within the scatter of the next); then compound 2.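

In this assay the replacement of azidomethyl by 2-(4-bromophenyl)ethenyl gives a 6.7-fold lower number from compound 2 to compound 3 (0.82 log units; beyond the scatter) at this aromatic carbon of the five-membered ring. Compound 3 stands within the scatter of compound 1, so among the compounds shown, the lower number at this position does not require the piperazinylmethyl arm: the two arms have in common a six-membered aromatic ring of carbon, which compound 2 lacks. No measurement here accounts for the step between these groups.

The compounds shown do not separate the contributions of the ring, the bromine and the ethenyl link, which a plain phenyl, a 4-chlorophenyl or a saturated ethyl link at this carbon would help to resolve. Going by these compounds, how a simple amine or a carboxylic acid at the same place compares also stays open.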